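The source may report more compounds than this note shows. Statements on the series, on what has been measured and on what is new or still open speak of the compounds shown alone.

Working notes on the series. In a functional assay on A549 cells (Homo sapiens) for inhibition, read by MTT assay, with a stated time of 48 h (a higher number here means a weaker inhibitor, a lower number a stronger inhibitor), compound 2 `CC(C)n1c(/C=C2\SC(=O)N(CC(=O)N3CCOCC3)C2=O)nc2ccccc21` gives > 50000 nM, which is a limit of the assay and not a number. It therefore sits at the limit of > 50000 nM in this assay, at which 1 of the 2 values shown sits. Compound 3 `CCn1c(/C=C2\SC(=O)N(CC(=O)N3CCOCC3)C2=O)nc2ccccc21` is the next to be read, and the change from compound 2 is hydrogen in place of methyl on a saturated chain carbon bound to an aromatic nitrogen and a saturated chain carbon, or isopropyl to ethyl. The ethyl group of compound 3 also occurs in compound 1 `CCn1c(/C=C2\SC(=O)N(CC(=O)Nc3cc(C(C)(C)C)on3)C2=O)nc2ccccc21`, which differs elsewhere and gives 44800 nM in this assay. No measured step sizes this change, so the expectation rests on these two readings. The expected change, a step that the limit leaves unreadable from compound 2 to compound 3, is estimated to stay within the usual scatter, with no direction favoured. For compound 3 the estimated value is 55000 nM, with an expected range of 30000 nM to 100000 nM.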

Compound 3, half-maximal inhibitory concentration: > 50000 nM
Compound 3 gave a limit, no number (the forecaster's own chance of this, stated with the estimate: 65%); the middle value does not contradict the limit.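

In this assay compound 3 gives (> 50000 nM), which is a limit of the assay and not a number. The change from isopropyl to ethyl on the saturated chain carbon therefore cannot be read in size or direction, and the morpholin-4-yl pair adds only a second compound at the same limit: the limit of > 50000 nM in this assay, at which 2 of the 3 values shown sit. The new information lies on the carbonyl carbon, where morpholin-4-yl in place of (5-(tert-butyl)-1,2-oxazol-3-yl)amino gives (an at least 1.1-fold higher number from compound 1 to compound 3 (0.04 log units; that floor lies within the scatter)), so the two groups are not separated in this assay.

Still open, as far as these compounds go, is how isopropyl and ethyl compare when the carbonyl carbon carries (5-(tert-butyl)-1,2-oxazol-3-yl)amino, the one setting with a numerical reading so far. Also open, from the compounds shown here alone, is whether a longer chain such as butyl on the aromatic nitrogen, or a piperazine on the carbonyl carbon, would give a number in this assay.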